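The source may report more compounds than this note shows. Statements on the series, on what has been measured and on what is new or still open speak of the compounds shown alone.

Measured so far:
- compound 1 `C[C@H]1CC[C@@H]2[C@@H](OC(=O)[C@]23CC(c2cccc([N+](=O)[O-])c2)=NO3)[C@]2(C)C(=O)C=C[C@@]12O`: 1.37
- compound 2 `Cc1ccccc1C1=NO[C@]2(C1)C(=O)O[C@@H]1[C@H]2CC[C@H](C)[C@]2(O)C=CC(=O)[C@@]12C`: 1.86

In a physicochemical assay for lipophilicity (a lower number here means a more polar compound, a higher number a more lipophilic compound), compound 2 stands highest of the two at 1.86, with compound 1 at 1.37. Next in line is compound 3 `Cc1cccc(C2=NO[C@]3(C2)C(=O)O[C@@H]2[C@H]3CC[C@H](C)[C@]3(O)C=CC(=O)[C@@]23C)c1`, with 3-methylphenyl in place of 2-methylphenyl on a carbon with a double bond to nitrogen. Within the data shown here, only one measured step bears on this change, and only indirectly: a number 0.49 log units higher from compound 1 to compound 2 (beyond the scatter), on swapping 3-nitrophenyl for 2-methylphenyl at that same carbon. Among the measured compounds shown here, that step exchanged a different group, and no measured pair shows a methyl group changing its place on the phenyl ring. A shift of the methyl alone is therefore expected to give a smaller step than that one, probably none beyond the scatter. The expected step is a number 0.09 log units higher from compound 2 to compound 3 (within the scatter). The estimate for compound 3 is 1.95, with an expected range of 1.65 to 2.25.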

Compound 3, partition coefficient: 1.86
Estimate against measurement, compound 3: 0.09 log units above, within the range that was stated.
By their numbers in this assay, from the lowest: compound 1; then compounds 2 and 3 (each within the scatter of the next).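

In this assay the exchange of 2-methylphenyl for 3-methylphenyl on the carbon with a double bond to nitrogen gives no change at the digits printed from compound 2 to compound 3 (within the scatter) and so separates neither compound from the other at this position. With the methyl group in place of nitro on an aromatic carbon, the reading is a number 0.49 log units higher from compound 1 to compound 3 (beyond the scatter) and matches in size a number 0.49 log units higher from compound 1 to compound 2 (beyond the scatter) so that, among these three compounds, the gap goes with the exchange of nitro for methyl and not with where the methyl stands on the phenyl ring. Nothing at hand accounts for either step.

Open, from the compounds shown here alone, is whether a methoxy group or an amine on the same phenyl ring would fall nearer compound 1 or nearer compounds 2 and 3. Also open, going by these compounds, is how an unsubstituted phenyl group at this carbon would compare with all three.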